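The source may hold more compounds than are shown below. What is called first, only, known or untested is meant among the compounds shown, and "the series" means these compounds.

Measured compounds:
compound 1, `CC(C)=CC(=O)NC(=N)NC(=O)C=C(C)C`, 21300 nM
compound 2, `CC(C)=CCC/C(C)=C/CC/C(C)=C/C(=O)NC(=N)N`, 9200 nM
compound 3, `C=C1CCCC(C)(C)[C@@H]1CC/C(C)=C/C(=O)NC(=N)NC(=O)C=C(C)C`, 9600 nM

In a functional assay on B16-F10 cells (Mus musculus) for inhibition, read by MTT assay, with a stated time of 72 h (a lower number here means a stronger inhibitor of growth, a higher number a weaker inhibitor of growth), compound 2 gives the lowest of the three numbers. Its value sits within the scatter of that of compound 3, so no order between the two can be drawn; compound 1 gives a higher number that lies beyond the scatter, and on that pair alone compound 2 is the stronger inhibitor of growth.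

Compound 4, `CC(C)=CCC/C(C)=C/C(=O)NC(=N)N`, has not yet been measured in this assay. It differs from compound 2 in one place: hydrogen in place of 3-methylbut-2-en-1-yl on a saturated chain carbon bound to a double-bonded chain carbon. Among the compounds with values here, no measured pair in this set shows what such a shortening of the chain does, so the expectation rests on compound 2 alone. The step of a 2.4-fold higher number from compound 2 to compound 4 (0.38 log units; beyond the scatter) is expected to be a moderate loss, somewhat beyond the scatter, because compound 2 with the full chain gives 9200 nM and the remaining compounds cluster in the same region. Compound 4 is estimated at 22000 nM, in a range from 8000 nM to 60000 nM.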

Compound 4, concentration for 50% growth inhibition: 17100 nM
Compound 4: the middle estimate sits 1.3-fold (0.11 log units) above what was measured, and the stated range covers the measured number.
By their numbers in this assay, from the lowest: compounds 2, 3, 4 and 1 (each within the scatter of the next, the first and the last beyond it).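

Replacing 3-methylbut-2-en-1-yl with hydrogen on a saturated chain carbon bound to a double-bonded chain carbon gives a 1.9-fold higher number from compound 2 to compound 4 (0.27 log units; within the scatter) in this assay. Within the data shown here, this is the first pair here that differs in one place, and it shows that this position can lose a group of 5 carbon atoms, including its double bond, without a difference that can be told from the scatter. No measurement shown here offers a reason for this result.

This single pair describes one replacement at one position, so it gives no general rule for the chain. From the compounds shown here alone, whether a longer chain, an amine or a carboxylic acid on the same saturated chain carbon would give a number distinct from those of compound 2 and compound 4 remains open.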